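Cyclopropyl for tert-butyl, with only limits to go on

The source may hold more compounds than are shown below. What is called first, only, known or untested is meant among the compounds shown, and "the series" means these compounds.

In an ADME assay on Huh-7 cells (Homo sapiens) for cytotoxicity, with a stated time of 72 h (on this read-out lower numbers stand for higher toxicity in this test and higher numbers for lower toxicity in this test), compound 1 (`CS(=O)(=O)Nc1ccc2c(c1)S(=O)(=O)N=C(c1c(O)c(-c3cccs3)nn(CC3CCC3)c1=O)N2`) gives > 1000 nM, which is a limit and not a number. Compound 2 (`COCCn1nc(-c2cccs2)c(O)c(C2=NS(=O)(=O)c3cc(NS(C)(=O)=O)ccc3N2)c1=O`) also gives only a limit, > 1000 nM. Compound 3 (`CC(C)(C)Cn1nc(-c2cccs2)c(O)c(C2=NS(=O)(=O)c3cc(NS(C)(=O)=O)ccc3N2)c1=O`) likewise gives only a limit, > 1000 nM. Taken together, the record reads: the limit of > 1000 nM in this assay, at which 3 of the 3 values shown sit.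

Compound 4 (`CS(=O)(=O)Nc1ccc2c(c1)S(=O)(=O)N=C(c1c(O)c(-c3cccs3)nn(CC3CC3)c1=O)N2`) is still to be measured. It differs from compound 3 by one change: cyclopropyl in place of tert-butyl on a saturated chain carbon bound to an aromatic nitrogen. Put simply, neopentyl gives way to cyclopropylmethyl.

Among the measured compounds shown here, three measured steps bear on this change, since each swaps the group at the same place: a step that the two limits leave unreadable from compound 1 to compound 2, a step that the two limits leave unreadable from compound 1 to compound 3 and a step that the two limits leave unreadable from compound 2 to compound 3. None of them has a size that can be carried over, so they point to no direction. No step beyond the usual scatter is expected in this assay. The estimated outcome is a step that the limit leaves unreadable from compound 3 to compound 4. Another limit is the most likely report. For compound 4 the expected value is 1500 nM, with an estimated range of 1000 nM to 5000 nM.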

Compound 4, half-maximal cytotoxic concentration: > 1000 nM
Compound 4 ended at the assay's limit; the forecaster's own chance of this, stated with the estimate: 85%; the middle value does not contradict the limit.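

No step among compound 1, compound 2, compound 3 and compound 4 can be read, since each result is a limit and not a number: the limit of > 1000 nM in this assay, at which 4 of the 4 values shown sit.

As far as these compounds go, whether changing the group on this saturated chain carbon alters the half-maximal cytotoxic concentration at all stays open.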